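A few compounds are considered here, and "the series" means these few. Any claim that something is new, unique, unknown or untested is made for them only; others in the source may bear on it.

Values in a physicochemical assay for solubility, at pH 7.4; on this read-out lower numbers stand for lower solubility and higher numbers for higher solubility

Compound 1 `Cc1cc(NC(=O)Nc2ccc(C(C)(C)C)cc2)c2ccccc2n1` gives 6200 nM
Compound 2 `Cc1cc(NC(=O)Nc2ccc(C(N)=O)cc2)c2ccccc2n1` gives 900 nM
Compound 3 `Cc1cc(NC(=O)Nc2ccc(C(=O)O)cc2)c2ccccc2n1` gives 9300 nM

Compound 3 shares the upper end of these three values with compound 1, and compound 2 lies clearly lower. The two steps behind this reading are a 1.5-fold higher number from compound 1 to compound 3 (0.18 log units; within the scatter) and a 10-fold higher number from compound 2 to compound 3 (1.01 log units; beyond the scatter) and only the second is large.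

The next structure is compound 4 `Cc1cc(NC(=O)Nc2ccc(C(=O)O)c(O)c2)c2ccccc2n1` and the change is hydroxy in place of hydrogen on an aromatic carbon with hydroxy in place of hydrogen on an aromatic carbon, ortho to a carboxy group. Among the measured compounds shown here, no measured step makes this change. The two steps above bear on it only loosely: both arrive at the carboxy group, and neither adds a group to the aromatic ring. The remaining step, a 6.9-fold lower number from compound 1 to compound 2 (0.84 log units; beyond the scatter) (modest), does not involve the carboxy group at all. Steps of such different size, none of them of the same kind, give no direction for this assay and so no shift beyond the scatter is expected. The expected step is a 1.0-fold lower number from compound 3 to compound 4 (0.01 log units; within the scatter) and its direction remains uncertain. Compound 4 is estimated at 9000 nM with an expected range from 3000 nM to 27000 nM as the likely span of a measurement.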

Compound 4, solubility: 26600 nM
Compound 4: middle estimate off by 3.0-fold (0.47 log units), on the low side; low and high end bracket the measured number.
By their numbers in this assay, from the lowest: compound 2; then compounds 1 and 3 (each within the scatter of the next); then compound 4.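

In this assay hydroxy in place of hydrogen on an aromatic carbon, ortho to a carboxy group and meta to a large group, gives a 2.9-fold higher number from compound 3 to compound 4 (0.46 log units; beyond the scatter) for this single added oxygen. Among the compounds shown here, the earlier steps only exchanged tert-butyl, carbamoyl and carboxy for one another, so this is the first sign that a further carbon of this ring can shift the number beyond the scatter while the carboxy group stays in place. Nothing on hand bears on why the number moves in this direction.

The compounds shown leave open whether the shift belongs to hydroxy itself or would also follow from methoxy, fluorine or an amine on the same carbon, and whether it depends on the carboxy group, as hydroxy appears here only alongside carboxy and not alongside carbamoyl or tert-butyl. Also open, as far as these compounds go, is whether hydroxy on another carbon of this ring, or a methyl ester in place of the carboxy group with hydroxy kept, would give a step of the same direction and size.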